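The compounds below may be only part of what the source reports. "The series", "measured", "known", "first", "only" and "open" are said of these compounds alone.

Measured compounds in an ADME assay on HCT-116 cells (Homo sapiens) for cytotoxicity, read by CellTiter-Glo, with a stated time of 72 h; a lower number here means a stronger inhibitor, a higher number a weaker inhibitor:
Compound 1, `CC1CCN(C2CCN(S(=O)(=O)c3cccnc3)CC2)CC1`: > 10000 nM, a limit of the assay.
Compound 2, `CC1CCN(C2CCN(S(=O)(=O)c3cccnc3F)CC2)CC1`: > 10000 nM, a limit of the assay.
Compound 3, `Cc1cc(C)c(S(=O)(=O)N2CCC(N3CCC(Cc4ccccc4F)CC3)CC2)c(C)c1`: > 5000 nM, a limit of the assay.

Compound 1 and compound 2 share a core and differ by hydrogen in place of fluoro on an aromatic carbon. In this assay compound 2 gives > 10000 nM, a limit. Compound 1 gives > 10000 nM, also a limit. The step that the two limits leave unreadable from compound 2 to compound 1 thus has no readable size, since both values sit at the limit of > 10000 nM in this assay, at which 2 of the 3 values shown sit. Compound 3 carries another core; how the two cores differ is not broken down here. In this assay compound 3 gives > 5000 nM, a limit as well, at the limit of > 5000 nM in this assay, at which 1 of the 3 values shown sits. Compound 4, `Cc1cc(C)c(S(=O)(=O)N2CCC(N3CCC(Cc4ccccc4)CC3)CC2)c(C)c1`, is not yet measured and differs from compound 3 by hydrogen in place of fluoro on an aromatic carbon. This is the same kind of change as from compound 2 to compound 1, but the place differs: in compound 2 the fluoro sits on a six-membered aromatic ring with 1 nitrogen, next to the ring nitrogen, whereas in compound 3 it sits on a six-membered aromatic ring of carbon only. With the earlier step unreadable, the step expected from compound 3 to compound 4 is a step that the limit leaves unreadable from compound 3 to compound 4, resting only on compound 3 at > 5000 nM. Compound 4 is therefore estimated at 20000 nM in this assay, between 5000 nM and 100000 nM, most likely reported again only as a limit.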

Compound 4, half-maximal inhibitory concentration: > 5000 nM
Compound 4: only a limit was reported; the forecaster's own chance of this, stated with the estimate: 85%; the middle value does not contradict the limit.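

In this assay, compound 4 stands at the same limit as compound 3, and neither gives a number: the limit of > 5000 nM in this assay, at which 2 of the 4 values shown sit. No size can be read for the step between compound 3 and compound 4. The compounds shown leave open whether hydrogen in place of fluoro changes the read-out in either pair, and at what concentration any of the four compounds would reach half-maximal inhibition.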